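Aryl-linker variation on the triazolopyridine series

The source may report more compounds than this note shows. Statements on the series, on what has been measured and on what is new or still open speak of the compounds shown alone.

Measured so far:
compound 1 `Clc1cc(-c2ccn3c(CC4CC4)nnc3c2Cl)ccc1NC1CC1` — 6.76 nM
compound 2 `Clc1cc(-c2ccn3c(CC4CC4)nnc3c2Cl)ccc1OC1CCOCC1` — 22.9 nM

Two compounds carry numbers in an assay on cells for displacement of a labelled ligand from metabotropic glutamate receptor 2 (Homo sapiens), read by scintillation counting, with a stated time of 60 min; a lower number here means a stronger inhibitor, a higher number a weaker inhibitor. Compound 1 gives 6.76 nM and compound 2 gives 22.9 nM; compound 2 thus has the higher of the two numbers, the step of a 3.4-fold higher number from compound 1 to compound 2 (0.53 log units; beyond the scatter) lying beyond the scatter.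

The next compound, compound 3 `Clc1cc(-c2ccn3c(CC4CC4)nnc3c2Cl)ccc1NC1CCOCC1`, follows from compound 2 by the change ((oxan-4-yl)amino in place of (oxan-4-yl)oxy on an aromatic carbon). For the measured compounds named here, no measured pair isolates this linker swap alone. Going by the values given here, the only step in hand, a 3.4-fold higher number from compound 1 to compound 2 (0.53 log units; beyond the scatter), changes both the linker and the ring on it at once, so it bears on the present step only in part: it shows that the amino-linked compound 1 sits at the lower number, and compound 3 restores an amino linker while keeping the oxan-4-yl ring of compound 2. An expected step in this assay toward a lower number, modest in size and not certainly beyond the scatter, is a 2.1-fold lower number from compound 2 to compound 3 (0.32 log units; beyond the scatter), because compound 1 gave 6.76 nM. Compound 3 is therefore estimated at 11 nM, with a range of 4 nM to 30 nM.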

Compound 3, inhibition constant: 38.9 nM
Beside the measured number, compound 3's estimate is 3.5-fold (0.55 log units) below it; measured number outside the range, above it.
By their numbers in this assay, from the lowest: compound 1; then compounds 2 and 3 (each within the scatter of the next).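

With the oxan-4-yl ring held constant, a 1.7-fold higher number from compound 2 to compound 3 (0.23 log units; within the scatter) in this assay means the oxy and amino linkers on this aromatic carbon, ortho to the chloro group, cannot be told apart in this pair. For the compounds shown here, with the amino linker held constant, a 5.8-fold higher number from compound 1 to compound 3 (0.76 log units; beyond the scatter) isolates the group on the nitrogen, and this step lies beyond the scatter, so the swap of cyclopropyl for oxan-4-yl is the only single change here with a resolved effect. Read together, these steps place the separation of compound 1 from compound 2 and compound 3 with the cyclopropyl group rather than with the linker atom alone, although this rests on only three compounds, and no data at hand speak to the origin of either step.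

Going by these compounds, whether the linker remains as indifferent when it carries cyclopropyl stays open. Also open, on these data alone, is how a piperidin-4-yl ring, a cyclobutyl ring or an open ethyl chain on the nitrogen would compare with cyclopropyl and oxan-4-yl in this position.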